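A cyano swap on the oxadiazole of compound 1

The compounds below may be only part of what the source reports. "The series", "measured", "known", "first", "only" and "open" are said of these compounds alone.

In a functional assay (aorta) with Rattus norvegicus as the target, in the presence of a further agent that is not named here (a higher number here means that more compound is needed for the effect, a lower number that less compound is needed), compound 1 `COC(=O)C1=C(C)N=C(C)/C(=C(/O)OC)C1c1cccc(OCc2nonc2C)c1` gives 640 nM. Compound 3 `COC(=O)C1=C(C)N=C(C)/C(=C(/O)OC)C1c1ccccc1OCc1no[n+]([O-])c1C(N)=O` gives 550 nM, which lies within the scatter of compound 1, while compound 2 `COC(=O)C1=C(C)N=C(C)/C(=C(/O)OC)C1c1ccccc1OCc1c(C)no[n+]1[O-]` gives 78 nM, a clearly smaller number than either.

Compound 4 `COC(=O)C1=C(C)N=C(C)/C(=C(/O)OC)C1c1cccc(OCc2nonc2C#N)c1` keeps the core of compound 1 and carries one change, (cyano in place of methyl on an aromatic carbon). This is cyano in place of methyl on an aromatic carbon, so that (4-methyl-1,2,5-oxadiazol-3-yl)methoxy becomes (4-cyano-1,2,5-oxadiazol-3-yl)methoxy.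

For the measured compounds named here, no measured step makes this exchange. The closest is a 7.1-fold higher number from compound 2 to compound 3 (0.85 log units; beyond the scatter), where a larger group replaces a smaller one on a saturated chain carbon bound to an oxygen on an aromatic ring. It is a weak guide, since compounds 2 and 3 differ from compound 1 in the group itself and in where it sits on the core. Going by the values given here, that step also ends at a number close to the one compound 1 already shows. No step beyond the scatter is therefore expected in this assay, and neither direction can be ruled out.

The expected change is a 1.4-fold lower number from compound 1 to compound 4 (0.15 log units; within the scatter). Compound 4 is estimated at 450 nM, with an expected range of 130 nM to 1500 nM.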

Compound 4, half-maximal effective concentration: 310 nM
For compound 4 the middle estimate is 1.5-fold (0.16 log units) above the measured one, within the range that was stated.
By their numbers in this assay, from the lowest: compound 2; then compounds 4, 3 and 1 (each within the scatter of the next, the first and the last beyond it).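

In this assay, a 2.1-fold lower number from compound 1 to compound 4 (0.31 log units; beyond the scatter). This is the only step shown that changes a substituent on the 1,2,5-oxadiazole of compound 1 while the rest of the molecule stays the same, and it concerns the aromatic carbon next to the ring atom that bears a large group. It shows that exchanging methyl for cyano at this carbon, which adds one hydrogen-bond acceptor, goes with a modest move towards a lower number, so the change did not cost activity here; nothing measured accounts for the step.

From the compounds shown here alone, a single exchange at one carbon gives no trend, so it remains open whether a carboxylic acid, an amine or a longer alkyl chain at this carbon would move the number in the same direction, or by a similar amount. Going by these compounds, it is also open whether the cyano exchange would have the same effect with the side chain attached to the core as in compound 2 and compound 3, which carry different ring groups and so cannot settle this.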